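Halogen swap on the aryl ketone of compound 2

The source may hold more compounds than are shown below. What is called first, only, known or untested is meant among the compounds shown, and "the series" means these compounds.

Three pyrazole chalcones have been tested in a functional assay on UACC-62 cells (Homo sapiens) for cytotoxicity, read by sulforhodamine B assay, with a stated time of 48 h, tested at 0.01 uM; on this read-out lower numbers stand for a stronger effect and higher numbers for a weaker effect at the one concentration tested. Compound 1 `COc1ccc(-c2cc(/C=C/C(=O)c3ccc(N)cc3)[nH]n2)cc1` gives 96%; compound 2 `COc1cc(-c2cc(/C=C/C(=O)c3ccc(Cl)c(Cl)c3)[nH]n2)cc(OC)c1OC` gives 97%; compound 3 `COc1ccc(C(=O)/C=C/c2cc(-c3cc(OC)c(OC)c(OC)c3)n[nH]2)cc1OC` gives 98%. Compound 2 lies within the scatter of both neighbours, so the three numbers are not separable.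

Compound 4 `COc1cc(-c2cc(/C=C/C(=O)c3ccc(F)c(F)c3)[nH]n2)cc(OC)c1OC` differs from compound 2 by 3,4-difluorophenyl in place of 3,4-dichlorophenyl on a carbonyl carbon. Going by the values given here, the only measured step at this place is a number 1 percentage points higher from compound 2 to compound 3 (within the scatter), a far larger swap of the aryl group that left the read-out unchanged. No step beyond the scatter is therefore expected for no change at the digits printed from compound 2 to compound 4 (within the scatter) in this assay .

Compound 4 is estimated at 97%, within 89% to 104%.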

Compound 4, a percentage reported as activity, at one concentration (the size of the read-out at that concentration, not a potency): 97%
The estimate for compound 4 equals the measured number at the digits printed; the range from low to high includes it.
By their numbers in this assay, from the lowest: compounds 1, 2, 4 and 3 (each within the scatter of the next).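

In this assay, exchanging the halogens on the aryl ketone gives no change at the digits printed from compound 2 to compound 4 (within the scatter), so the chlorine pair and the fluorine pair cannot be told apart at this place. The second new comparison gives a number 1 percentage points lower from compound 3 to compound 4 (within the scatter), which extends this to 3,4-difluorophenyl and 3,4-dimethoxyphenyl on the same carbonyl carbon. No evidence on the cause of this result is available.

Going by these compounds, it remains open whether a carboxylic acid or a nitrile on this aryl ring would move the read-out beyond the scatter.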